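Urea series on the triazole nitrogen: benzyl to methylcyclohexyl

The source may hold more compounds than are shown below. What is called first, only, known or untested is meant among the compounds shown, and "the series" means these compounds.

Compound 1 `O=C(NCc1ccccc1)N(Cc1ccccn1)n1cnnc1` has been tested in a functional assay on MDA-MB-231 cells (Homo sapiens) for cytotoxicity, read by MTT assay, with a stated time of 48 h; a higher number here means a weaker inhibitor, a lower number a stronger inhibitor. In this assay compound 1 returns only the assay limit, > 50000 nM. Compound 3 `COc1cc(CN(C(=O)Nc2ccc(C)cc2)n2cnnc2)cc(OC)c1OC` likewise stops at the limit, > 50000 nM. Among the compounds with values here, compound 2 `Cc1ccsc1CN(C(=O)Nc1ccc(Cl)c(C(F)(F)F)c1)n1cnnc1` is the one member with a number, giving 29600 nM. Compound 1 therefore stands at the weak end of what has been measured, sharing the limit of > 50000 nM in this assay, at which 2 of the 3 values shown sit, with compound 3; no numbered value for compound 1 exists, so its distance from compound 2 cannot be stated.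

Compound 4 `CC1CCC(NC(=O)N(Cc2ccccn2)n2cnnc2)CC1` differs from compound 1 by 4-methylcyclohexyl in place of benzyl on an amide-type nitrogen. Within the data shown here, no measured pair in this assay shows an exchange of this kind, and the starting point sits at the limit, so there is no baseline to move from. The expected step of a number no higher from compound 1 to compound 4 (the limit leaves the size open) is none beyond the scatter. Compound 4 is estimated at 50000 nM, within 20000 nM to 120000 nM, and is expected most likely to return only a limit again.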

Compound 4, half-maximal inhibitory concentration: 33200 nM
Estimate against measurement, compound 4: 1.5-fold (0.18 log units) above, within the range that was stated.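

In this assay, the amide-type nitrogen of this series gives a numbered value with a non-aromatic ring in place: compound 4 gives 33200 nM. Replacing benzyl with 4-methylcyclohexyl there, with no change in the hydrogen-bond donors or acceptors counted for the group, gives an at least 1.5-fold lower number from compound 1 to compound 4 (0.17 log units; that floor lies within the scatter), so the exchange cannot be called a real gain on the printed floor. The value of compound 1 is a limit, which leaves the true size of the step open: the limit of > 50000 nM in this assay, at which 2 of the 4 values shown sit.

The compounds shown leave open whether the methyl on the ring matters, which a plain cyclohexyl on the same nitrogen would address. They also leave open whether a longer chain such as n-hexyl, or an amine or carboxylic acid on the ring, would move the value beyond the scatter.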